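The source may hold more compounds than are shown below. What is called first, only, known or untested is meant among the compounds shown, and "the series" means these compounds.

Measured so far:
compound 1 `CCOC(=O)N1CCC(=NNC(=O)c2ccc(F)cc2)CC1` — 65600 nM
compound 2 `O=C(NN=C1CC(c2ccccc2)NC(c2ccccc2)C1)c1ccccc1` — 41900 nM

Two compounds have numbers in a functional assay for inhibition, read by spectrophotometry, with a stated time of 120 min; a lower number here means a stronger inhibitor, a higher number a weaker inhibitor. Compound 1 gives 65600 nM in this assay. Compound 2 gives 41900 nM in this assay, the lower of the two numbers, but the gap to compound 1 is within the usual scatter, so the two cannot be ordered on these values. Both sit in a weak region of the scale.

Compound 3 `O=C(NN=C1CC(c2ccccc2)NC(c2ccccc2)C1)c1ccc(F)cc1C(F)(F)F` keeps the core of compound 2 and differs only at the carbonyl carbon: 4-fluoro-2-(trifluoromethyl)phenyl in place of phenyl on a carbonyl carbon. Within the data shown here, no pair of measured compounds differs in one place, so there is no measured step to lean on, and the change itself, 4-fluoro-2-(trifluoromethyl)phenyl in place of phenyl, has no precedent among the two compounds. The expectation is therefore a small shift, on the stronger side if anything, that may well stay inside the scatter. Compound 3 is estimated at 30000 nM in this assay, within 9000 nM to 100000 nM. The expected step of a 1.4-fold lower number from compound 2 to compound 3 (0.15 log units; within the scatter) is modest and uncertain in direction.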

Compound 3, half-maximal inhibitory concentration: 115000 nM
Compound 3: middle estimate off by 3.8-fold (0.58 log units), on the low side, and the stated range ends below it.
By their numbers in this assay, from the lowest: compounds 2, 1 and 3 (each within the scatter of the next, the first and the last beyond it).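

In this assay, among these compounds, the exchange of phenyl for 4-fluoro-2-(trifluoromethyl)phenyl on a carbonyl carbon gives a 2.7-fold higher number from compound 2 to compound 3 (0.44 log units; beyond the scatter) and is the first change that can be read in one place. It shows that the number at this position depends on the group carried there, and that this larger group, with 11 heavy atoms against 6 for phenyl, moves the compound towards weaker inhibition rather than stronger. No accompanying measurement bears on the origin of this step.

The compounds shown leave open whether the fluoro part, the trifluoromethyl part or the two together account for the higher number, as this single step carries both at once. They also leave open whether any group on this carbonyl carbon can give a lower number than phenyl does on the core of compound 2, for example an aminophenyl, a carboxylic acid on the phenyl ring, a pyridine ring or a short alkyl chain in place of the ring.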